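Variation of the sulfonyl aryl group across three analogues

The source may report more compounds than this note shows. Statements on the series, on what has been measured and on what is new or still open speak of the compounds shown alone.

Measured so far:
compound 1, `O=S(=O)(Nc1ccc(-c2nc3ccccc3o2)cc1)c1ccc(Cl)s1`: 31000 nM
compound 2, `O=S(=O)(Nc1ccc(-c2nc3ccccc3o2)cc1)c1ccccc1Cl`: > 100000 nM, a limit
compound 3, `O=S(=O)(Nc1ccc(-c2nc3ccccc3o2)cc1)c1ccc(Cl)cc1`: 61000 nM

In an assay on cells for inhibition of HSP60/HSP10 (Homo sapiens), with a stated time of 60 min (on this read-out higher numbers stand for weaker inhibition and lower numbers for stronger inhibition), compound 1 gives 31000 nM. Compound 2 returns only > 100000 nM, which is a limit of the assay and not a number. Compound 3 gives 61000 nM, the highest of the two numbers, with compound 1 nearest; the step of a 2.0-fold higher number from compound 1 to compound 3 (0.29 log units; within the scatter) stays within the scatter. The step of an at least 3.2-fold higher number from compound 1 to compound 2 (0.50 log units; beyond the scatter) is the only one beyond the scatter, and it rests on (the limit of > 100000 nM in this assay, at which 1 of the 3 values shown sits). Between the two chlorophenyl groups the step of an at least 1.6-fold lower number from compound 2 to compound 3 (0.21 log units; that floor lies within the scatter) has a floor that lies within the scatter.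

Compound 4, `Cc1ccc(S(=O)(=O)Nc2ccc(-c3nc4ccccc4o3)cc2)cc1`, differs from compound 3 by methyl in place of chloro on an aromatic carbon. Going by the values given here, none of the measured steps changes a substituent on one ring; all exchange the whole aryl group on the sulfonyl sulfur, and the two steps free of a limit are within the scatter. The step of a 1.1-fold higher number from compound 3 to compound 4 (0.06 log units; within the scatter) is therefore expected to be small, with no direction beyond the scatter. Compound 4 is estimated at 70000 nM, between 25000 nM and 200000 nM.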

Compound 4, half-maximal inhibitory concentration: > 100000 nM
Compound 4: no number, only a limit (the forecaster's own chance of this, stated with the estimate: 30%); middle value at least 1.4-fold (0.15 log units) from the limit.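

Compound 4 gives > 100000 nM in this assay, which is a limit of the assay and not a number. Going by these compounds alone, this is the first change on the ring itself and not of the whole aryl group, and the step of an at least 1.6-fold higher number from compound 3 to compound 4 (0.21 log units; that floor lies within the scatter) shows only that exchanging chloro for methyl on this ring does not keep a number within the assay's range, with no size fixed. The step of an at least 3.2-fold higher number from compound 1 to compound 4 (0.50 log units; beyond the scatter) gives a second aryl group, after 2-chlorophenyl, that reads beyond the scatter from 5-chlorothiophen-2-yl, while the step between compound 2 and compound 4 cannot be read, and all of these readings rest on one boundary: the limit of > 100000 nM in this assay, at which 2 of the 4 values shown sit.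

Open, as far as these compounds go, is whether methyl in place of chloro on the 5-chlorothiophen-2-yl group of compound 1 behaves the same way. Also open, from the compounds shown here alone, is whether an amine or a carboxylic acid in place of the chloro of compound 3 would return a number and not a limit.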